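The source may report more compounds than this note shows. Statements on the series, on what has been measured and on what is new or still open speak of the compounds shown alone.

Measured in a physicochemical assay for solubility, in phosphate buffer, with a stated time of 2 h, at pH 7.4; on this read-out higher numbers stand for higher solubility and lower numbers for lower solubility:
- compound 1 `Cc1ccc(Nc2nc(-c3ccccn3)cs2)nc1`: 10000 nM
- compound 2 `Clc1ccc(Nc2nc(-c3ccccn3)cs2)nc1`: < 10000 nM (a limit)
- compound 3 `COc1ccnc(-c2csc(Nc3ccc(Cl)cn3)n2)c1`: < 10000 nM (a limit)

Compound 2 has no exact number in this assay. Its only entry is the limit < 10000 nM. Compound 3 is also known only by a limit, < 10000 nM. The wider picture is short: the limit of < 10000 nM in this assay, at which 2 of the 3 values shown sit.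

For the measured compounds named here, the next compound to be tested is compound 4 `COc1ccc(-c2csc(Nc3ccc(Cl)cn3)n2)nc1`, which has no measurement yet. It differs from compound 2 by one change: methoxy in place of hydrogen on an aromatic carbon. In words, this is methoxy in place of hydrogen on an aromatic carbon.

Two measured steps are available. The closer guide is the same kind of change in compound 3, recorded as a step that the two limits leave unreadable from compound 2 to compound 3. It gives no size to carry over. The other is a number no higher from compound 1 to compound 2 (the limit leaves the size open), a chloro in place of methyl, which is a different change and also has no readable size. On these data alone, with no measured size to build on, no step beyond the usual scatter is expected in this assay, and the direction stays open. The expected change is a step that the limit leaves unreadable from compound 2 to compound 4. For compound 4 the estimated value is 5000 nM, with an expected range from 1000 nM to 12000 nM.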

Compound 4, solubility: < 10000 nM
Compound 4: no number, only a limit; the forecaster's own chance of this, stated with the estimate: 75%; the middle value does not contradict the limit.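

In this assay compound 4 gives < 10000 nM, which is a limit and not an exact number. Compound 2 also has only a limit, so no step can be read between compound 2 and compound 4. The compounds shown leave open whether methoxy in place of hydrogen on an aromatic carbon moves this read-out at all, and in which direction: the limit of < 10000 nM in this assay, at which 3 of the 4 values shown sit.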